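Aryl amide to aryl urea swap on the hydrazide chain

The compounds below may be only part of what the source reports. "The series", "measured", "known", "first", "only" and "open" are said of these compounds alone.

Compound 3 `COc1cc(NC(C)CCCNC(=O)NNC(=O)/C=C/c2ccc(OC)c(OC)c2)c2ncccc2c1` is the hydrazide member of the series. In an ADME assay on L6 cells (Rattus norvegicus) for cytotoxicity, read by resazurin assay, with a stated time of 70 h (a higher number here means a weaker inhibitor, a lower number a stronger inhibitor), compound 3 gives 37000 nM, the highest of the two numbers recorded; the nearest is compound 2 `COc1cc(NC(C)CCCNC(=O)/C=C/c2cccc(C(F)(F)F)c2)c2ncccc2c1`, which in this assay gives 16200 nM. Compound 1 `COc1cc(NC(C)CCCNC(=O)/C=C/c2ccc(OC)c(OC)c2)c2ncccc2c1` is reported in this assay only as a limit, > 220000 nM, and not as a number (the limit of > 220000 nM in this assay, at which 1 of the 3 values shown sits).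

Compound 4 `COc1cc(NC(C)CCCNC(=O)NNC(=O)Nc2ccc(C(F)(F)F)cc2)c2ncccc2c1` is the next candidate. It differs from compound 3 as follows: (4-(trifluoromethyl)phenyl)amino in place of 2-(3,4-dimethoxyphenyl)ethenyl on a carbonyl carbon.

Among the measured compounds shown here, one measured step bears on this change. an at least 13-fold lower number from compound 1 to compound 2 (1.13 log units; beyond the scatter) shows that exchanging a dimethoxyphenyl for a trifluoromethylphenyl group on the chain lowered the number strongly, although there the double-bonded chain stayed in place, whereas in compound 4 the ethenyl leaves and an aryl amino enters on the carbonyl carbon, a part of the change for which no measured step exists. The aryl swap alone is taken as the main guide, tempered for the untested amino linkage, so a lowering beyond the scatter but smaller than an at least 13-fold lower number from compound 1 to compound 2 (1.13 log units; beyond the scatter) is expected.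

Compound 4 is therefore estimated at 9000 nM in this assay, within 3000 nM to 30000 nM, which is expected to correspond to a 4.1-fold lower number from compound 3 to compound 4 (0.61 log units; beyond the scatter).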

Compound 4, half-maximal inhibitory concentration: 14900 nM
Estimate against measurement, compound 4: 1.7-fold (0.22 log units) below, and the stated range covers the measured number.
By their numbers in this assay, from the lowest: compounds 4 and 2 (each within the scatter of the next); then compound 3. At a limit, above all of these: compound 1.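

On the carbonyl carbon of the hydrazide chain, (4-(trifluoromethyl)phenyl)amino in place of 2-(3,4-dimethoxyphenyl)ethenyl gives a 2.5-fold lower number from compound 3 to compound 4 (0.40 log units; beyond the scatter) in this assay, so this position also responds to an exchange of the aryl group, though here the step is modest. The amide pair showed an at least 13-fold lower number from compound 1 to compound 2 (1.13 log units; beyond the scatter), but that step changed only the aryl group and kept the double-bonded chain, whereas the step on the hydrazide chain changes the aryl group, its substitution and the linkage to the carbonyl carbon together. No measured property in the data shown accounts for the size of this step.

The shares of the aryl exchange and of the amino linkage therefore stay unresolved; (3,4-dimethoxyphenyl)amino on the same carbonyl carbon would separate them from the ethenyl linkage of compound 3. Also open, going by these compounds, is how far the reading for compound 4 depends on the 4-(trifluoromethyl) group, which a 4-chlorophenyl or a 4-cyanophenyl on the same amino linkage would test, and how a longer chain in place of the present one would read.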